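A few compounds are considered here, and "the series" means these few. Any claim that something is new, unique, unknown or untested is made for them only; others in the source may bear on it.

Measured compounds:
compound 1 `Cc1nc(SCC(=O)Nc2nc(-c3ccc(Cl)cc3)cs2)n(Nc2ccccc2)c1C`: 13500 nM
compound 2 `Cc1ccc(Nn2c(SCC(=O)Nc3nc(-c4ccccc4)cs3)nc(C)c2C)cc1`: > 100000 nM

Going by the values given here, in a functional assay on OVCAR-5 cells (Homo sapiens) for antiproliferative activity, read by sulforhodamine B assay, with a stated time of 48 h (a higher number here means a weaker inhibitor of growth, a lower number a stronger inhibitor of growth), compound 1 gives 13500 nM, the only actual number in the set. Compound 2 reaches only the limit of > 100000 nM in this assay, a limit rather than a number (the limit of > 100000 nM in this assay, at which 1 of the 2 values shown sits).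

Compound 3 `COc1ccc(Nn2c(SCC(=O)Nc3nc(-c4ccc(Cl)cc4)cs3)nc(C)c2C)cc1` differs from compound 1 by methoxy in place of hydrogen on an aromatic carbon. Among the compounds with values here, no measured step of this kind exists, so the expectation rests on compound 1 alone. A modest loss is expected, of about a 1.9-fold higher number from compound 1 to compound 3 (0.27 log units; within the scatter) in this assay. Compound 3 is thus estimated at 25000 nM, within a range of 8000 nM to 100000 nM.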

Compound 3, concentration for total growth inhibition: > 100000 nM
Compound 3: only a limit was reported; the forecaster's own chance of this, stated with the estimate: 30%; middle value at least 4.0-fold (0.60 log units) away from the limit.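

In this assay, the change of phenyl to 4-methoxyphenyl on the anilino group gives an at least 7.4-fold higher number from compound 1 to compound 3 (0.86 log units; beyond the scatter), so this place on the ring is not indifferent to substitution in the context of compound 1. Compound 3 carries a limit and not a number, so the step sets only a floor on the size of the change: the limit of > 100000 nM in this assay, at which 2 of the 3 values shown sit.

Open, on these data alone, is whether any group at this place gives such a step or whether it is specific to methoxy. Fluorine or a hydroxyl group here would help separate the two.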